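The source may report more compounds than this note shows. Statements on the series, on what has been measured and on what is new or still open speak of the compounds shown alone.

Compound 1 `CCCc1nc(C)c2c(C)nn(C)c(=O)n12` and compound 2 `CCCc1nc(C)c2c(C)nn(CCC)c(=O)n12` share one core; compound 3 `CCCc1nnc(S)n2c(CCC)nc(C)c12` and compound 4 `CCCc1nc(C)c2c(C)nnc(S)n12` share another, and the difference between the two cores is not broken down here. In a functional assay for inhibition, with Homo sapiens as the target (on this read-out lower numbers stand for stronger inhibition and higher numbers for weaker inhibition), compound 1 gives only a limit of the assay, > 48000 nM. Compound 2 likewise reaches only a limit, > 48000 nM. The change from compound 2 to compound 1 is hydrogen in place of ethyl on a saturated chain carbon bound to an aromatic nitrogen, and the step that the two limits leave unreadable from compound 2 to compound 1 is left without a readable size by the two limits; every value shown so far sits at the limit of > 48000 nM in this assay, at which 3 of the 3 values shown sit. Compound 3 too gives only a limit in this assay, > 48000 nM. From compound 3 to compound 4 the change is hydrogen in place of ethyl on a saturated chain carbon bound to an aromatic carbon; it is the same kind of change as that from compound 2 to compound 1, though the place differs, a saturated chain carbon bound to an aromatic carbon rather than one bound to an aromatic nitrogen. With all values known resting at the limit of > 48000 nM in this assay, at which 3 of the 3 values shown sit, compound 4 is expected to sit there as well, with an estimated step that the limit leaves unreadable from compound 3 to compound 4 that carries little meaning. The estimate for compound 4 in this assay is 70000 nM, expected to lie between 20000 nM and 300000 nM.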

Compound 4, half-maximal inhibitory concentration: 45000 nM
Compound 4: the middle estimate sits 1.6-fold (0.19 log units) above what was measured; measured number inside the range.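

In this assay, hydrogen in place of ethyl on a saturated chain carbon bound to an aromatic carbon gives an at least 1.0-fold lower number from compound 3 to compound 4 (0.02 log units; that floor lies within the scatter), so this step shows no change that can be told from the scatter, although the true size could be larger. The same kind of change on the other core, on a saturated chain carbon bound to an aromatic nitrogen, links compound 2 and compound 1, and that step cannot be read, as both values are limits. The compounds therefore show neither that the change carries from one core to the other nor that it fails to, and most values rest at one limit: the limit of > 48000 nM in this assay, at which 3 of the 4 values shown sit.

Compound 4 gives 45000 nM in this assay. Going by these compounds, whether any group on either core would give a value clearly beyond the scatter from that of compound 4 remains open. An amine, a carboxylic acid or a chain longer than propyl could test this, and the same swap on both cores at the same place would allow a direct comparison.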